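A few compounds are considered here, and "the series" means these few. Any claim that something is new, unique, unknown or untested is made for them only; others in the source may bear on it.

Measured in a functional assay on aorta (Rattus norvegicus, strain Sprague-Dawley); a higher number here means that more compound is needed for the effect, a lower number that less compound is needed:
- compound 1 `Cc1nn(-c2ccccc2)c2nc(OCc3ccccc3F)c(-c3nc(N)cc(N)n3)cc12`: 2200 nM
- compound 2 `Cc1nn(-c2ccccc2)c2nc(OCc3ccccc3F)c(-c3nc(N)c(N4CCCC4)c(N)n3)cc12`: 12700 nM
- compound 3 `Cc1nn(-c2ccccc2)c2nc(OCc3ccccc3F)c(-c3nc(N)c(N)c(N)n3)cc12`: 960 nM

Compound 3 has the lowest number of the three. Compound 4 `Cc1nn(-c2ccccc2)c2nc(OCc3ccccc3F)c(-c3nc(N)c(N4CCOC4=O)c(N)n3)cc12` differs from it at one place: 2-oxo-1,3-oxazolidin-3-yl in place of amino on an aromatic carbon. The 2-oxo-1,3-oxazolidin-3-yl group replaces the amino group on an aromatic carbon, ortho to two amino groups.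

Going by the values given here, no measured compound carries this group. The closest guide is the exchange of pyrrolidin-1-yl, also a five-membered ring, for amino at this carbon: a 13-fold lower number from compound 2 to compound 3 (1.12 log units; beyond the scatter). Two modest steps frame it: a 5.8-fold higher number from compound 1 to compound 2 (0.76 log units; beyond the scatter) and a 2.3-fold lower number from compound 1 to compound 3 (0.36 log units; beyond the scatter). Losing the amino group is therefore expected to raise the number in this assay, probably by less than the largest step seen. The estimated change is a 6.3-fold higher number from compound 3 to compound 4 (0.80 log units; beyond the scatter). For compound 4 the expected value is 6000 nM, within an estimated range of 1800 nM to 20000 nM.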

Compound 4, half-maximal effective concentration: > 100000 nM
Compound 4: only a limit was reported; the forecaster's own chance of this, stated with the estimate: 10%; middle value at least 16-fold (1.22 log units) from the limit.
By their numbers in this assay, from the lowest: compound 3; then compound 1; then compound 2. At a limit, above all of these: compound 4.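

In this assay compound 4 gives only a limit, not a number: the limit of > 100000 nM in this assay, at which 1 of the 4 values shown sits. Putting the 2-oxo-1,3-oxazolidin-3-yl group on this carbon costs far more than any earlier change there, with an at least 100-fold higher number from compound 3 to compound 4 (2.01 log units; beyond the scatter) against amino and an at least 45-fold higher number from compound 1 to compound 4 (1.65 log units; beyond the scatter) against hydrogen. It also differs from the other five-membered ring, with an at least 7.8-fold higher number from compound 2 to compound 4 (0.89 log units; beyond the scatter), so ring size alone does not set the outcome at this carbon.

Which part of the ring matters remains open. A pyrrolidin-2-one or a morpholine here could separate the effects of the carbonyl and the ring oxygen, and methylamino would test a small change to the amino group.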